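The source may hold more compounds than are shown below. What is called first, only, known or untested is meant among the compounds shown, and "the series" means these compounds.

Working notes on the series. Of the compounds shown here, three sharing one core have been measured in a functional assay on OVCAR-8 cells (Homo sapiens) for antiproliferative activity; a higher number here means a weaker inhibitor, a lower number a stronger inhibitor. Compound 1 (`Cn1ncc(Cl)c1-c1cc(C(=O)N[C@@H]2CN[C@H](CCCO)C[C@H]2c2ccc(Cl)c(Cl)c2)oc1Cl`) gives 600 nM and compound 2 (`Cn1ncc(Cl)c1-c1cc(C(=O)N[C@@H]2CN[C@H](CC(=O)NC3CC3)C[C@H]2c2ccc(Cl)c(Cl)c2)oc1Cl`) gives 580 nM, and the two are indistinguishable, with a 1.0-fold lower number from compound 1 to compound 2 (0.01 log units; within the scatter). Compound 3 (`Cn1ncc(Cl)c1-c1cc(C(=O)N[C@@H]2CN[C@H](CC(=O)NCCO)C[C@H]2c2ccc(Cl)c(Cl)c2)oc1Cl`) stands highest of the three at 1450 nM, which makes it the weakest inhibitor so far.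

Compound 4 (`COCC[C@@H]1C[C@@H](c2ccc(Cl)c(Cl)c2)[C@H](NC(=O)c2cc(-c3c(Cl)cnn3C)c(Cl)o2)CN1`) is still unmeasured. Its difference from compound 3 is methoxymethyl in place of (2-hydroxyethyl)carbamoyl on a saturated chain carbon bound to a saturated ring carbon.

The most relevant measured step is a 2.4-fold higher number from compound 1 to compound 3 (0.38 log units; beyond the scatter). Read in reverse, it also leaves the (2-hydroxyethyl)carbamoyl for a chain without a carbamoyl. The second relevant step is a 2.5-fold higher number from compound 2 to compound 3 (0.40 log units; beyond the scatter), but compound 2 keeps a carbamoyl, so it goes against tying the shift to loss of the carbamoyl alone. Within the data shown here, no measured compound carries methoxymethyl. A modest step of similar size towards a lower number is therefore expected in this assay, though it may not clear the scatter by much.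

The expected change is a 2.2-fold lower number from compound 3 to compound 4 (0.35 log units; beyond the scatter). For compound 4 the estimated value is 650 nM, with an expected range of 300 nM to 1400 nM.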

Compound 4, half-maximal inhibitory concentration: 1060 nM
Compound 4: middle estimate off by 1.6-fold (0.21 log units), on the low side; the range from low to high includes it.
By their numbers in this assay, from the lowest: compounds 2, 1, 4 and 3 (each within the scatter of the next, the first and the last beyond it).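

In this assay, methoxymethyl in place of (2-hydroxyethyl)carbamoyl on a saturated chain carbon bound to a saturated ring carbon gives a step within the scatter (a 1.4-fold lower number from compound 3 to compound 4 (0.14 log units; within the scatter)), so removing the carbamoyl from compound 3 does not by itself separate the two compounds. Compound 4 also lies within the scatter of the two other compounds (a 1.8-fold higher number from compound 2 to compound 4 (0.26 log units; within the scatter); a 1.8-fold higher number from compound 1 to compound 4 (0.25 log units; within the scatter)), which shows that this position accepts a 2-methoxyethyl chain as well as the chain of compound 1 or the cyclopropyl amide chain of compound 2, and that methoxy in place of hydroxymethyl makes no readable change. Among these compounds, compound 3 thus remains the only compound with steps beyond the scatter, but only against compound 1 and compound 2, and no information is available to explain the small spread across this position.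

From the compounds shown here alone, it remains open whether a carboxylic acid or a dimethylamino group at the end of this chain would move the number beyond the scatter in this assay. Also open, going by these compounds, is whether a longer chain, such as 4-methoxybutyl, would keep the number within the scatter of compound 4.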